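The compounds below may be only part of what the source reports. "The series", "measured", "known", "first", "only" and "open" are said of these compounds alone.

Measured so far in a functional assay on MDA-MB-435S cells (Homo sapiens) for antiproliferative activity, read by MTT assay, with a stated time of 72 h; a higher number here means a weaker inhibitor, a lower number a stronger inhibitor:
- compound 1 `O=c1c(CSC(=S)N2CCN(c3ccccc3)CC2)coc2ccccc12`: 9700 nM
- compound 2 `O=c1c(CSC(=S)N2CCCC2)coc2ccccc12`: 3800 nM

Compound 2 stands at the lower of the two numbers in this assay, and its gap to compound 1 lies beyond the usual scatter of repeated measurements. Going by the values given here, the two compounds share the core of compound 1 and differ only in the amine on the thiocarbonyl carbon; no single-change step between them is set out, so only the two values speak.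

Compound 3 `CN1CCN(C(=S)SCc2coc3ccccc3c2=O)CC1` is not yet measured. It differs from compound 2 by 4-methylpiperazin-1-yl in place of pyrrolidin-1-yl on a thiocarbonyl carbon. With compound 1, which also carries a piperazine on that position, sitting at the higher number, a move upward from compound 2 is expected, though of a size that may not clear the scatter, since the methyl is a smaller substituent than phenyl.

For compound 3 the estimate in this assay is 6000 nM, within 2500 nM to 15000 nM, meaning an expected step of a 1.6-fold higher number from compound 2 to compound 3 (0.20 log units; within the scatter).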

Compound 3, half-maximal inhibitory concentration: 2200 nM
For compound 3 the middle estimate is 2.7-fold (0.44 log units) above the measured one; measured number below the stated range.
By their numbers in this assay, from the lowest: compounds 3 and 2 (each within the scatter of the next); then compound 1.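

In this assay, a piperazine on the thiocarbonyl carbon does not by itself go with the higher number: 4-methylpiperazin-1-yl in place of pyrrolidin-1-yl gives a 1.7-fold lower number from compound 2 to compound 3 (0.24 log units; within the scatter) and leaves the two amines unresolved at this position. Within the piperazine pair, the group on the ring amine nitrogen matters, since methyl in place of phenyl gives a 4.4-fold lower number from compound 1 to compound 3 (0.64 log units; beyond the scatter) and this step is the only one of the two beyond the scatter. Nothing at hand gives a reason for either step.

Open, on these data alone, is how other groups on that ring nitrogen, such as ethyl, benzyl or acetyl, would fall relative to methyl and phenyl. Also open, as far as these compounds go, is whether morpholin-4-yl or piperidin-1-yl on the thiocarbonyl carbon would stay level with pyrrolidin-1-yl.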